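Removing the Dimethylamino Group from Compound 3

A few compounds are considered here, and "the series" means these few. Any claim that something is new, unique, unknown or untested is made for them only; others in the source may bear on it.

Of the compounds shown here, three sharing one core have been measured in a functional assay on LS174T cells (Homo sapiens) for inhibition, with a stated time of 4 days, tested at 10 uM; a lower number here means a weaker effect, a higher number a stronger effect of the compound at the concentration tested. Compound 1 `Fc1cccc(F)c1C#Cc1ccc2nccc(Cl)c2c1` gives 89.7% there, and compound 2 `Nc1ccnc2ccc(C#Cc3c(F)cccc3F)cc12` gives 93.9%; the step of a number 4.2 percentage points higher from compound 1 to compound 2 (within the scatter) separates them. Compound 3 `CN(C)c1ccc2cc(C#Cc3c(F)cccc3F)ccc2n1` gives 38.7%, the lowest of the three numbers, beyond the scatter below both compound 1 and compound 2.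

Compound 4 `Fc1cccc(F)c1C#Cc1ccc2ncccc2c1` is the unmeasured one. It differs from compound 3 by hydrogen in place of dimethylamino on an aromatic carbon. Among the compounds with values here, no measured step touches this group or this place on the core: the only step recorded, a number 4.2 percentage points higher from compound 1 to compound 2 (within the scatter), concerns a different position and lies within the scatter, so it cannot say how much of the low number of compound 3 comes from the dimethylamino group itself. Whether compound 4 returns toward the level of compound 1 and compound 2 or stays near compound 3 is therefore open, and the expected step of a number 19.3 percentage points higher from compound 3 to compound 4 (beyond the scatter) carries a broad range. The estimate for compound 4 in this assay is 58%, between 22% and 92%.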

Compound 4, a percentage reported as inhibition, at one concentration (the size of the read-out at that concentration, not a potency): 80.1%
Beside the measured number, compound 4's estimate is 22.1 percentage points below it; the range from low to high includes it.
By their numbers in this assay, from the lowest: compound 3; then compounds 4, 1 and 2 (each within the scatter of the next, the first and the last beyond it).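

In this assay, hydrogen in place of dimethylamino next to the ring nitrogen gives a number 41.4 percentage points higher from compound 3 to compound 4 (beyond the scatter) and so ties the low number of compound 3 to that group, since the core without it keeps a high number. At the other substituted position, hydrogen in place of amino gives a number 13.8 percentage points lower from compound 2 to compound 4 (beyond the scatter), a modest drop that separates these two groups. Hydrogen in place of chloro gives a number 9.6 percentage points lower from compound 1 to compound 4 (within the scatter), so these two groups cannot be told apart at that position.

From the compounds shown here alone, whether a single methyl group or a plain amino group next to the ring nitrogen would also lower the number remains open. Nothing available explains any of these steps.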